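Hydroxy in place of methoxy on the pyrazole series

A few compounds are considered here, and "the series" means these few. Any claim that something is new, unique, unknown or untested is made for them only; others in the source may bear on it.

Compound 1 `Cc1cc(O)cc(-c2nn(CC#N)cc2-c2ccnc(-c3ccc(Oc4ccccc4)cc3)c2)c1` and compound 2 `COc1cc(C)cc(-c2nn(CC#N)cc2-c2ccnc(-c3ccc(N(C)C)cc3)c2)c1` carry the same core. In a functional assay on SF-295 cells (Homo sapiens) for cytotoxicity, read by sulforhodamine B assay, with a stated time of 48 h, tested at 0.01 uM (a lower number here means a stronger effect, a higher number a weaker effect of the compound at the concentration tested), compound 1 gives 94% and compound 2 gives 94%, so compound 2 is level with compound 1 at the digits shown, within the scatter. Compound 3 `Cc1cc(O)cc(-c2nn(CC#N)cc2-c2ccnc(-c3ccc(N(C)C)cc3)c2)c1` differs from compound 2 by hydrogen in place of methyl on an oxygen on an aromatic ring. Among the measured compounds shown here, no step between measured compounds shows this change on its own; both measured values sit at the same weak level, so no step beyond the scatter is expected. The expected step from compound 2 to compound 3 is a number 1 percentage points lower from compound 2 to compound 3 (within the scatter). For compound 3 the estimate in this assay is 93%, ranging from 82% to 102%.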

Compound 3, a percentage reported as activity, at one concentration (the size of the read-out at that concentration, not a potency): 89%
Beside the measured number, compound 3's estimate is 4 percentage points above it, and the stated range covers the measured number.
By their numbers in this assay, from the lowest: compounds 3, 1 and 2 (each within the scatter of the next).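

Read in this assay the change from methoxy to hydroxy gives a number 5 percentage points lower from compound 2 to compound 3 (within the scatter) and so does not separate the free hydroxy from its methyl ether at this concentration. Dimethylamino in place of phenoxy on the aromatic carbon gives a number 5 percentage points lower from compound 1 to compound 3 (within the scatter) and likewise separates nothing, so neither position yet shows a measurable effect. Nothing at hand bears on a reason for these results.

Open, from the compounds shown here alone, is whether a larger ether such as benzyloxy, or an amine in place of the hydroxy, would move the read-out. Also open, going by these compounds, is whether these compounds differ at higher concentrations.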